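This account rests on a few compounds, and the source may have more. Where it says the series, first, only, none or still open, it means among the compounds named here.

Compound 2 `Cc1[nH]c2ccc(F)cc2c1C1=CCNCC1` stands as the weaker of the two measured compounds: in an assay on isolated protein for displacement of a labelled ligand from 5-hydroxytryptamine receptor 7 (Homo sapiens) (on this read-out higher numbers stand for weaker inhibition and lower numbers for stronger inhibition), compound 2 gives 3100 nM, whereas compound 1 `Cc1[nH]c2ccc(Br)cc2c1C1=CCNCC1` gives 480 nM. For the measured compounds named here, the single measured step, a 6.5-fold higher number from compound 1 to compound 2 (0.81 log units; beyond the scatter), is the only one that bears on the next change. Compound 3 `Cc1[nH]c2ccccc2c1C1=CCNCC1` differs from compound 2 by hydrogen in place of fluoro on an aromatic carbon. Because a 6.5-fold higher number from compound 1 to compound 2 (0.81 log units; beyond the scatter) already weakened binding when one halogen replaced another, taking the halogen away altogether is expected to leave the number near that of compound 2 or somewhat higher. The expected step is therefore a 1.3-fold higher number from compound 2 to compound 3 (0.11 log units; within the scatter). Compound 3 is estimated at 4000 nM in this assay, with a range from 1300 nM to 12000 nM.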

Compound 3, half-maximal inhibitory concentration: > 1000 nM
Compound 3: no number, only a limit; the forecaster's own chance of this, stated with the estimate: 5%; the middle value does not contradict the limit.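

Compound 3 gives a limit and not a number: the limit of > 1000 nM in this assay, at which 1 of the 3 values shown sits.

The step from fluoro to hydrogen cannot be read, so this position does not show whether removing fluoro changes binding at all. The change from bromo to hydrogen can be read, as an at least 2.0-fold higher number from compound 1 to compound 3 (0.31 log units; beyond the scatter), so that losing bromo from this aromatic carbon, like replacing it with fluoro, goes with weaker binding.

Going by these compounds, whether chloro, iodo or methoxy on this aromatic carbon would match bromo remains open. So does the effect of a nitrile or a longer chain here.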